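Oxime ether series on HCT-116 growth: toward compound 4

This account rests on a few compounds, and the source may have more. Where it says the series, first, only, none or still open, it means among the compounds named here.

Compound 1 `COc1cc2c(cc1CC=C(C)C)C(=O)C[C@@H](c1ccc(Oc3ccccc3)cc1)O2`: in a functional assay on HCT-116 cells (Homo sapiens) for inhibition, read by sulforhodamine B assay, with a stated time of 48 h, tested at 50 uM (a lower number here means less inhibition of growth, a higher number more inhibition of growth at the concentration tested), compound 1 gives 76%.
Compound 2 `CCOc1ccc([C@@H]2CC(=O)c3cc(CC=C(C)C)c(OC)cc3O2)cc1`: compound 2 gives 65%.
Compound 3 `C#CCO/N=C1/C[C@@H](c2ccc(OC)cc2)Oc2cc(OC)c(CC=C(C)C)cc21`: compound 3 gives 65%.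

Compound 3 stands level with compound 2 at the digits shown, the two together lowest of the three; compound 1 lies higher, and the only single step in the set, a number 11 percentage points lower from compound 1 to compound 2 (beyond the scatter), is modest.

Compound 4 `COc1ccc([C@@H]2C/C(=N/OCc3cn(-c4ccc(O)cc4)nn3)c3cc(CC=C(C)C)c(OC)cc3O2)cc1` differs from compound 3 by 1-(4-hydroxyphenyl)-1H-1,2,3-triazol-4-yl in place of ethynyl on a saturated chain carbon bound to an oxygen on an unsaturated carbon. For the measured compounds named here, no measured step touches the oxime ether chain, so the step from compound 1 to compound 2 bears only as a guide to scale: a single-point change moved the read-out modestly. For a much larger entering group a step of similar or somewhat larger size is expected, direction uncertain, estimated as a number 5 percentage points lower from compound 3 to compound 4 (within the scatter).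

Compound 4 is expected to give 60%, range 35% to 85%.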

Compound 4, percent growth inhibition at one concentration: 65%
For compound 4 the middle estimate is 5 percentage points below the measured one; the range from low to high includes it.
By their numbers in this assay, from the lowest: compounds 2, 3 and 4 (each within the scatter of the next); then compound 1.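

In this assay there is no change at the digits printed from compound 3 to compound 4 (within the scatter) when 1-(4-hydroxyphenyl)-1H-1,2,3-triazol-4-yl replaces ethynyl on a saturated chain carbon bound to an oxygen on an unsaturated carbon. For the compounds shown here, this position thus takes a much larger group, with two aromatic rings and a hydrogen-bond donor, without a readable shift at the concentration tested; no earlier step touched this chain. Nothing available explains this tolerance.

Open: whether an amine or a carboxylic acid in place of the hydroxyl on the phenyl ring would hold this level, and whether a longer chain before the triazole would do so.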